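Tolerance notes: methyl added beside the benzyl amide nitrogen

The compounds below may be only part of what the source reports. "The series", "measured", "known", "first", "only" and "open" are said of these compounds alone.

Measured so far:
Compound 1 `CCC[C@H](NC(=O)[C@@H]1C[C@@H]2CN1C(=O)[C@H](C(C)(C)C)NC(=O)OCCCCCCc1cccc3c1CN(C3)C(=O)O2)C(=O)C(=O)NC1CCC1` — in an ADME assay on Huh-7 cells (Homo sapiens) for cytotoxicity (a lower number here means that less compound is tolerated, a higher number that more compound is tolerated), compound 1 is reported only as the assay limit > 50000 nM.
Compound 2 `CCC[C@H](NC(=O)[C@@H]1C[C@@H]2CN1C(=O)[C@H](C(C)(C)C)NC(=O)OCCCCCCc1cccc3c1CN(C3)C(=O)O2)C(=O)C(=O)NCc1ccccc1` — in this assay compound 2 is likewise reported only as the assay limit > 50000 nM.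

Compound 2 therefore stands at the limit and nowhere else on the numbers shown. Within the data shown here, the one measured step, a step that the two limits leave unreadable from compound 1 to compound 2, has no readable size, due to the limit of > 50000 nM in this assay, at which 2 of the 2 values shown sit. Nothing in the measured pair tells whether a change at the amide-type nitrogen moves tolerance in either direction.

Compound 3 `CCC[C@H](NC(=O)[C@@H]1C[C@@H]2CN1C(=O)[C@H](C(C)(C)C)NC(=O)OCCCCCCc1cccc3c1CN(C3)C(=O)O2)C(=O)C(=O)NC(C)c1ccccc1` differs from compound 2 by methyl in place of hydrogen on a saturated chain carbon bound to an amide-type nitrogen and an aromatic carbon. Among the measured compounds shown here, the only step that bears on this change is a step that the two limits leave unreadable from compound 1 to compound 2, and it gives no magnitude. With no readable step to build on, the expectation is that compound 3 remains at the limit, with no step beyond the scatter; the expected step of a number no higher from compound 2 to compound 3 (the limit leaves the size open) is set accordingly. The estimate for compound 3 is 50000 nM, with an expected range from 20000 nM to 100000 nM, and a high chance that only a limit is reported again.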

Compound 3, half-maximal cytotoxic concentration: > 50000 nM
Compound 3: only a limit was reported; the forecaster's own chance of this, stated with the estimate: 80%; the middle value lies on the limit itself.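

No step among compound 1, compound 2 and compound 3 can be read in this assay, due to a shared limit: the limit of > 50000 nM in this assay, at which 3 of the 3 values shown sit.

The compounds shown leave open whether benzyl to 1-phenylethyl, or any other change on the amide-type nitrogen, moves tolerance in either direction, and where the half-maximal cytotoxic concentration of each compound actually lies.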